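This account rests on a few compounds, and the source may have more. Where it says the series, first, only, none or still open, it means among the compounds named here.

Measured in a functional assay on Ramos cells (Homo sapiens) for antiproliferative activity, read by CCK-8 assay, with a stated time of 72 h, tested at 40 uM; a higher number here means more inhibition at the concentration tested (going by the name of the read-out), a lower number less inhibition:
compound 1, `CCOC(=O)c1sc(-c2cccc(NC(=O)c3ccc(C(C)(C)C)cc3)c2)nc1Nc1ccc(N2CCN(C)CC2)cc1`, 21.2%
compound 2, `CCOC(=O)c1sc(-c2cccc(NC(=O)c3cccc(F)c3)c2)nc1Nc1ccc(N2CCN(C)CC2)cc1`, 85.2%
compound 3, `CN1CCN(c2ccc(Nc3nc(-c4cccc(NC(=O)c5cccc(F)c5)c4)sc3C(=O)O)cc2)CC1`, 82.7%

Compound 3 sits close to compound 2, the step of a number 2.5 percentage points lower from compound 2 to compound 3 (within the scatter) lying within the scatter, and far above compound 1. Compound 4, `CN1CCN(c2ccc(Nc3nc(-c4cccc(NC(=O)c5ccc(F)c(Cl)c5)c4)sc3C(=O)O)cc2)CC1`, differs from compound 3 by 3-chloro-4-fluorophenyl in place of 3-fluorophenyl on a carbonyl carbon. Among the compounds with values here, the only measured step at the same place is a number 64 percentage points higher from compound 1 to compound 2 (beyond the scatter), which shows that the group on the carbonyl carbon can move the read-out strongly; that step, however, exchanged 4-(tert-butyl)phenyl for 3-fluorophenyl, whereas the entering 3-chloro-4-fluorophenyl keeps the fluorine of the leaving group and adds a chlorine. Within the data shown here, no measured step tests such an addition. A modest change in this assay is therefore expected, direction uncertain; the expected step is a number 4.7 percentage points lower from compound 3 to compound 4 (within the scatter). Compound 4 is thus expected to give 78%, between 55% and 92%.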

Compound 4, a percentage reported as inhibition, at one concentration (the size of the read-out at that concentration, not a potency): 98.6%
Beside the measured number, compound 4's estimate is 20.6 percentage points below it; the whole stated range lies below it.
By their numbers in this assay, from the lowest: compound 1; then compounds 3 and 2 (each within the scatter of the next); then compound 4.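

In this assay, the step to 3-chloro-4-fluorophenyl on the carbonyl carbon gives a number 15.9 percentage points higher from compound 3 to compound 4 (beyond the scatter). The earlier step at this place, a number 64 percentage points higher from compound 1 to compound 2 (beyond the scatter), exchanged 4-(tert-butyl)phenyl for 3-fluorophenyl; this one shows that a change of a single added chlorine, with a fluorine still on the ring, also moves the read-out beyond the scatter. No measurement at hand accounts for the gain.

Open, on these data alone, is whether 3-chlorophenyl, without fluorine, would give the same read-out. Also open, as far as these compounds go, is whether an ethyl ester in place of the carboxylic acid would change the result with 3-chloro-4-fluorophenyl.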